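Taking a methoxy group off a growth-inhibiting compound

The compounds below may be only part of what the source reports. "The series", "measured", "known", "first", "only" and "open" are said of these compounds alone.

In a functional assay on HCT-116 cells (Homo sapiens) for inhibition, read by sulforhodamine B assay, with a stated time of 48 h, tested at 50 uM (a higher number here means more inhibition of growth at the concentration tested, a lower number less inhibition of growth), compound 2 `COc1ccccc1/C=C/C(=O)/C=C/c1ccc(OCc2cn(CCCOc3cc(=O)oc4ccccc34)nn2)c(OC)c1` gives 53% at the single concentration tested. Compound 1 `COc1ccc(/C=C/C(=O)/C=C/c2ccc(OCc3cn(CCCCOc4cc(=O)oc5ccccc45)nn3)c(OC)c2)cc1OC` gives 55% in this assay as well, and these two numbers lie within the usual scatter of each other, so neither can be ranked above the other. They differ in more than one place, so the pair does not show the effect of any single change.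

Compound 3 `COc1cc(/C=C/C(=O)/C=C/c2ccccc2)ccc1OCc1cn(CCCOc2cc(=O)oc3ccccc23)nn1` is not yet measured. It differs from compound 2 by hydrogen in place of methoxy on an aromatic carbon in one place: hydrogen in place of methoxy on an aromatic carbon, so 2-methoxyphenyl becomes phenyl. Within the data shown here, no measured pair isolates this change, so no shift beyond the scatter is expected and no direction can be argued. The estimated a number 3 percentage points lower from compound 2 to compound 3 (within the scatter) stays within the scatter. The estimate for compound 3 is 50% with an expected range from 35% to 65% in this assay.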

Compound 3, percent growth inhibition at one concentration: 45%
Compound 3: the middle estimate sits 5 percentage points above what was measured; the measured number falls inside the stated range.
By their numbers in this assay, from the lowest: compounds 3, 2 and 1 (each within the scatter of the next).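

Among these compounds, this is the first pair that differs in one place only, and it isolates the methoxy group of the 2-methoxyphenyl ring: replacing it with hydrogen, so that the ring becomes phenyl, gives a number 8 percentage points lower from compound 2 to compound 3 (within the scatter) in this assay. At the single concentration tested, this methoxy group therefore cannot be shown to matter, and compound 3 cannot be ranked apart from compound 2. No measurement shown here offers an explanation for this result.

From the compounds shown here alone, whether an amine, a carboxylic acid or a trifluoromethyl group on this same ring carbon would shift the number beyond the scatter remains open. Also open, going by these compounds, is what the linking chain contributes on its own, since compound 1 and compound 2 differ in more than one place.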